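From piperidin-1-yl to 4-hydroxypiperidin-1-yl in compound 4

This account rests on a few compounds, and the source may have more. Where it says the series, first, only, none or still open, it means among the compounds named here.

Compound 3 `O=C1Nc2c(C(F)(F)F)cccc2C1(c1ccc(O)cc1)N1CCCCC1` gives > 1000000 nM in a functional assay on MCF7 cells (Homo sapiens) for inhibition, read by resazurin assay, with a stated time of 24 h (on this read-out higher numbers stand for weaker inhibition and lower numbers for stronger inhibition), which is a limit and not a number. Compound 1 `O=C1Nc2c(C(F)(F)F)cccc2C1(c1ccc(OC(F)(F)F)cc1)c1cc(F)c(O)c(F)c1` gives > 1000 nM in this assay, again a limit. Compound 2 `O=C1Nc2c(C(F)(F)F)cccc2C1(c1ccc(OC(F)(F)F)cc1)c1ccc(OC(F)(F)F)cc1` gives > 1000 nM, also a limit. Compound 4 `O=C1Nc2c(C(F)(F)F)cccc2C1(c1ccc(O)cc1)N1CCC(O)CC1` carries hydroxy in place of hydrogen on a saturated ring carbon, so that piperidin-1-yl becomes 4-hydroxypiperidin-1-yl. Going by the values given here, the only measured step, a step that the two limits leave unreadable from compound 1 to compound 2, changes a different group and has no readable size, so it offers no size to carry over. No step beyond the scatter is therefore expected, in either direction. The expected step is a number no higher from compound 3 to compound 4 (the limit leaves the size open). For compound 4 the estimate is 1000000 nM, with an expected range from 200000 nM to 5000000 nM.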

Compound 4, half-maximal inhibitory concentration: > 1000000 nM
Compound 4 was reported as a limit (the forecaster's own chance of this, stated with the estimate: 75%); the middle value sits exactly at the limit.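

In this assay compound 3 gives > 1000000 nM, which is a limit. Going by these compounds alone, compound 4 gives > 1000000 nM, also a limit, so no step from compound 3 to compound 4 can be read. The compounds shown leave open whether 4-hydroxypiperidin-1-yl and piperidin-1-yl differ at all.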